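The compounds below may be only part of what the source reports. "The series", "measured", "known", "first", "only" and "open" are said of these compounds alone.

In an assay on CHO-K1 cells for antagonist activity at transient receptor potential cation channel subfamily V member 1 (Homo sapiens), read by FLIPR and calcium flux, with a stated time of 6 min (on this read-out lower numbers stand for stronger inhibition and higher numbers for weaker inhibition), three compounds built on a shared core have been measured. Compound 1 `Cn1ncc2c(NC(=O)NCc3cc(C(F)(F)F)nn3-c3cccc(F)c3)cccc21` gives 7 nM. Compound 2 `Cn1ncc2c(NC(=O)NCc3cc(C(F)(F)F)nn3-c3cccc(C(F)(F)F)c3)cccc21` gives 1.4 nM. Compound 3 `Cn1ncc2c(NC(=O)NCc3cc(C(F)(F)F)nn3-c3ccc(Cl)cc3)cccc21` gives 2.7 nM. Compound 3 thus holds the second highest number of the three: a 2.6-fold lower number from compound 1 to compound 3 (0.41 log units; beyond the scatter), while a 1.9-fold higher number from compound 2 to compound 3 (0.29 log units; within the scatter), so compound 2 and compound 3 cannot be told apart. Compound 4 `Cn1ncc2c(NC(=O)NCc3cc(C(F)(F)F)nn3-c3ccc(C(F)(F)F)cc3)cccc21` has not yet been measured; it differs from compound 3 in one place: trifluoromethyl in place of chloro on an aromatic carbon. Within the data shown here, two measured steps bear on this change. The nearest is the exchange of a small group for a trifluoromethyl group, seen where a 5.0-fold lower number from compound 1 to compound 2 (0.70 log units; beyond the scatter). The other is a 1.9-fold higher number from compound 2 to compound 3 (0.29 log units; within the scatter), which shows that a chloro group and a trifluoromethyl group, each on its own phenyl ring, gave numbers within the scatter of one another. Here the departing group is chloro rather than fluoro, and the one measured exchange of chloro against trifluoromethyl stayed within the scatter, so a shift smaller than that from compound 1 to compound 2 is expected. For compound 4 the step is estimated as a 1.7-fold lower number from compound 3 to compound 4 (0.23 log units; within the scatter), a lowering that may not pass beyond the scatter. Compound 4 is therefore expected to give about 1.6 nM, within a range from 0.5 nM to 5 nM.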

Compound 4, inhibition constant: 3.9 nM
Beside the measured number, compound 4's estimate is 2.4-fold (0.39 log units) below it, and the stated range covers the measured number.
By their numbers in this assay, from the lowest: compounds 2, 3, 4 and 1 (each within the scatter of the next, the first and the last beyond it).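

In this assay, the exchange of chloro for trifluoromethyl on an aromatic carbon, para to a large group, gives a 1.4-fold higher number from compound 3 to compound 4 (0.16 log units; within the scatter), so at this place on the ring the two groups cannot be told apart. Among these compounds, the place of the trifluoromethyl group on the ring does show: 4-(trifluoromethyl)phenyl in place of 3-(trifluoromethyl)phenyl gives a 2.8-fold higher number from compound 2 to compound 4 (0.44 log units; beyond the scatter), which lies beyond the scatter and is the first step that moves one group while keeping its identity. The 4-(trifluoromethyl)phenyl group also gives a 1.8-fold lower number from compound 1 to compound 4 (0.25 log units; within the scatter) against 3-fluorophenyl, within the scatter, whereas the 3-(trifluoromethyl)phenyl group gave a 5.0-fold lower number from compound 1 to compound 2 (0.70 log units; beyond the scatter), beyond it, so the gain seen with trifluoromethyl over fluoro does not carry over to the other place on the ring.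

No measurement shown offers a reason for any of these steps. Still open, going by these compounds, is whether chloro or fluoro would depend on its place on the ring as trifluoromethyl does, and whether a methoxy group, an amine or a carboxylic acid on that same aromatic carbon would stay within the scatter of chloro and trifluoromethyl.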